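Thiophene for Methoxyphenyl on a Bis-Aryl Imidazopyrazine Core

This account rests on a few compounds, and the source may have more. Where it says the series, first, only, none or still open, it means among the compounds named here.

Compound 1 `COc1ccc(-c2cn3ccnc3c(-c3ccc4ncn(C5CCCCC5)c4c3)n2)cc1` gives 83.2% in a functional assay on 786-0 cells (Homo sapiens) for inhibition, read by sulforhodamine B assay, with a stated time of 48 h, tested at 10 uM; on this read-out higher numbers stand for more inhibition at the one concentration tested (going by the name of the read-out) and lower numbers for less inhibition.
Compound 2 `O=Cc1ccc(-c2cn3ccnc3c(-c3ccc4ncn(C5CCCCC5)c4c3)n2)cc1` gives 46.7% in this assay.
Compound 3 `Brc1ccc(-c2cn3ccnc3c(-c3ccc4ncn(C5CCCCC5)c4c3)n2)cc1` gives 18% in this assay.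

Compound 1 stands highest of the three in this assay; compound 2 comes nearest a number 36.5 percentage points lower from compound 1 to compound 2 (beyond the scatter), compound 3 furthest a number 65.2 percentage points lower from compound 1 to compound 3 (beyond the scatter). Compound 4 `c1csc(-c2cn3ccnc3c(-c3ccc4ncn(C5CCCCC5)c4c3)n2)c1` is unmeasured and differs from compound 1 as follows: thiophen-2-yl in place of 4-methoxyphenyl on an aromatic carbon. Among the compounds with values here, no measured step swaps the whole aryl group; the two that change only the substituent on it both lower inhibition, a number 36.5 percentage points lower from compound 1 to compound 2 (beyond the scatter) and a number 65.2 percentage points lower from compound 1 to compound 3 (beyond the scatter), so every departure from compound 1 seen so far has cost. Compound 4 is therefore expected to show a drop, estimated as a number 28.2 percentage points lower from compound 1 to compound 4 (beyond the scatter), though the size of this step is uncertain. Compound 4 is estimated at 55%, within 25% to 85%.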

Compound 4, a percentage reported as inhibition, at one concentration (the size of the read-out at that concentration, not a potency): 4.1%
For compound 4 the middle estimate is 50.9 percentage points above the measured one, and the stated range ends above it.
By their numbers in this assay, from the lowest: compound 4; then compound 3; then compound 2; then compound 1.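

Exchanging the whole aryl group, rather than only its substituent, gives the largest fall seen at this position in this assay, a number 79.1 percentage points lower from compound 1 to compound 4 (beyond the scatter). The thiophen-2-yl group also falls short of the two other substituted phenyl groups, a number 13.9 percentage points lower from compound 3 to compound 4 (beyond the scatter) and a number 42.6 percentage points lower from compound 2 to compound 4 (beyond the scatter), so compound 4 stands lowest of the four. No evidence given here accounts for this fall.

From the compounds shown here alone, it remains open whether an unsubstituted phenyl, or a phenyl carrying an ethoxy group or an amine, would hold the inhibition of compound 1. Also open, going by these compounds, is whether a methoxy group on the thiophene would recover any of it.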